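A few compounds are considered here, and "the series" means these few. Any claim that something is new, unique, unknown or untested is made for them only; others in the source may bear on it.

Measured compounds:
compound 1, `COCc1ccccc1C(=O)c1oc2cc(-c3ccccc3)cc(O)c2c1C`, 0.1 ug/mL
compound 2, `COc1ccc(C(=O)c2oc3cc(-c4ccccc4)cc(O)c3c2C)cc1OC`, 0.45 ug/mL

In a functional assay on WI-38 VA13 cells (Homo sapiens) for cytotoxicity (a higher number here means that more compound is needed for the effect, a lower number that less compound is needed), compound 1 gives the lower of the two numbers; compound 2 gives a number beyond the scatter above it. Compound 3, `COc1ccccc1C(=O)c1oc2cc(-c3ccccc3)cc(O)c2c1C`, differs from compound 1 by methoxy in place of methoxymethyl on an aromatic carbon. Among the measured compounds shown here, no step of this kind has been measured, so the direction is uncertain; a step of modest size, likely within the scatter or a little beyond it, is expected from compound 1, as a 1.5-fold higher number from compound 1 to compound 3 (0.18 log units; within the scatter). For compound 3 the estimate in this assay is 0.15 ug/mL, with a range from 0.05 ug/mL to 0.5 ug/mL.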

Compound 3, half-maximal effective concentration: 0.09 ug/mL
The estimate for compound 3 lay 1.7-fold (0.22 log units) above the measured number; low and high end bracket the measured number.
By their numbers in this assay, from the lowest: compounds 3 and 1 (each within the scatter of the next); then compound 2.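

In this assay, replacing methoxymethyl with methoxy gives a 1.1-fold lower number from compound 1 to compound 3 (0.05 log units; within the scatter). At this place, on an aromatic carbon ortho to a large group, the two groups therefore cannot be told apart, which compound 1 and compound 2 could not show because they differ in more than one place. Nothing at hand gives a reason for this match.

Going by these compounds, it remains open whether this place would accept an amine, a carboxylic acid or a longer chain equally well. On these data alone, it is also open whether the match between methoxy and methoxymethyl would hold elsewhere on this ring.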